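A few compounds are considered here, and "the series" means these few. Any claim that something is new, unique, unknown or untested is made for them only; others in the source may bear on it.

Working notes on the series. Within the data shown here, in a functional assay on MCF7 cells (Homo sapiens) for inhibition, read by CCK-8 assay, with a stated time of 48 h (on this read-out higher numbers stand for weaker inhibition and lower numbers for stronger inhibition), compound 1 `COc1cc(-c2ccnc3cc(-c4ccc(C)cc4)nn23)cc(OC)c1OC` gives 47 nM, the middle of the three numbers so far. Compound 2 `COc1cc(-c2ccnc3cc(-c4ccc5c(ccn5C)c4)nn23)cc(OC)c1OC` gives 3 nM, and compound 3 `COc1cc(-c2ccnc3cc(-c4cn(C)c5ccccc45)nn23)cc(OC)c1OC` gives 95 nM. Compound 4 `CCOC(=O)c1ccc(-c2cc3nccc(-c4cc(OC)c(OC)c(OC)c4)n3n2)cc1` is still to be measured; its change is ethoxycarbonyl in place of methyl on an aromatic carbon, para to a large group.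

Two measured steps replace the whole 4-methylphenyl group: a 16-fold lower number from compound 1 to compound 2 (1.19 log units; beyond the scatter) and a 2.0-fold higher number from compound 1 to compound 3 (0.31 log units; beyond the scatter). The gap between those replacements is also wide, a 32-fold higher number from compound 2 to compound 3 (1.50 log units; beyond the scatter). Changes at this place can therefore be large, but they run in both directions. Among the measured compounds shown here, no measured compound carries ethoxycarbonyl, and no measured step keeps 4-methylphenyl's six-membered ring while changing only its methyl, so the direction remains a judgement. The expected change is a 3.8-fold higher number from compound 1 to compound 4 (0.58 log units; beyond the scatter), an estimated modest to large step toward weaker inhibition, with wide uncertainty. For compound 4 the estimate is 180 nM, with an expected range from 40 nM to 800 nM.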

Compound 4, half-maximal inhibitory concentration: > 10000 nM
Compound 4: a limit, no number (the forecaster's own chance of this, stated with the estimate: 5%); middle value at least 55-fold (1.74 log units) away from the limit.
By their numbers in this assay, from the lowest: compound 2; then compound 1; then compound 3. At a limit, above all of these: compound 4.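

The earlier steps shown here replaced the whole 4-methylphenyl group, whereas here the six-membered ring stays and only its group para to a large group changes: in this assay, ethoxycarbonyl in place of methyl gives an at least 210-fold higher number from compound 1 to compound 4 (2.32 log units; beyond the scatter). This position is therefore sensitive to the group on the ring, and not only to the choice of ring, and this single change is larger than either step that replaced the whole group. The result for compound 4 is a limit of the assay and not a number: the limit of > 10000 nM in this assay, at which 1 of the 4 values shown sits.

As far as these compounds go, the full size of this step therefore stays open. With only methyl and ethoxycarbonyl shown at this place, it also remains open how methoxycarbonyl, a carboxylic acid or an amine there would read.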